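Methoxy in place of fluoro on compound 2

The source may hold more compounds than are shown below. What is called first, only, known or untested is meant among the compounds shown, and "the series" means these compounds.

Values so far in a functional assay on Fem-X cells (Homo sapiens) for cytotoxicity, read by MTT assay, with a stated time of 72 h; a higher number here means a weaker inhibitor, a lower number a stronger inhibitor
compound 1 `COc1ccc(Nc2ccc3ccccc3n2)cc1` gives 43000 nM
compound 2 `Cc1ccc(-c2ccnc(Nc3ccc(F)cc3)c2)cc1` gives 79000 nM
compound 3 `COc1ccc(Nc2cc(-c3cccc(C(F)(F)F)c3)ccn2)cc1` gives 68000 nM

Compound 2 (79000 nM) stands within the scatter of both compound 3 (68000 nM) and compound 1 (43000 nM), so no order among the three can be read.

Compound 4 (`COc1ccc(Nc2cc(-c3ccc(C)cc3)ccn2)cc1`) has not been measured yet. It differs from compound 2 by methoxy in place of fluoro on an aromatic carbon, para to a large group (methoxy in place of fluoro on an aromatic carbon). Among the compounds with values here, no measured pair differs in one place only, so the series gives no direct reading of such a change.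

The expectation rests on the close values of the three measured compounds. In this assay no step beyond the scatter is expected, and neither direction is favoured. The estimate means a 1.3-fold lower number from compound 2 to compound 4 (0.12 log units; within the scatter) as the expected step, which stays within the scatter. Compound 4 is estimated at 60000 nM with an expected range from 25000 nM to 120000 nM here.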

Compound 4, half-maximal inhibitory concentration: 33000 nM
Estimate against measurement, compound 4: 1.8-fold (0.26 log units) above; the measured number falls inside the stated range.
By their numbers in this assay, from the lowest: compounds 4, 1, 3 and 2 (each within the scatter of the next, the first and the last beyond it).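

In this assay the series now has its first comparison that differs in one place: on an aromatic carbon para to a large group, methoxy in place of fluoro gives a 2.4-fold lower number from compound 2 to compound 4 (0.38 log units; beyond the scatter) as a modest step. Within the data shown here, the three earlier compounds, with no such pair among them, could not show that a change at this position can move the number beyond the scatter. Nothing among the data available bears on the reason for this step.

From the compounds shown here alone, this remains a single step at a single position, so it sets no trend; whether an amine, a hydroxyl or a longer chain such as ethoxy on the same carbon would follow the same direction stays open. Also open, going by these compounds, is whether fluoro in place of methoxy on compound 3 would give a step of similar size.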